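Cyclohexylcarbamoyl for dimethylcarbamoyl: cytotoxicity notes on the series

The source may report more compounds than this note shows. Statements on the series, on what has been measured and on what is new or still open speak of the compounds shown alone.

Measured so far:
compound 1 `C[C@H](NC(=O)[C@]1(Cc2ccccc2)CCN1C(=O)OCc1ccccc1)C(=O)N(C)C` gives > 100000 nM, a limit of the assay.
compound 2 `C[C@H](NC(=O)[C@]1(Cc2ccccc2)CCN1C(=O)Oc1cccc2ccccc12)C(N)=O` gives > 100000 nM, a limit of the assay.
compound 3 `C[C@H](NC(=O)[C@@]1(Cc2ccccc2)CCN1C(=O)OCc1ccccc1)C(=O)N(C)C` gives > 100000 nM, a limit of the assay.

In an ADME assay on HELF cells (Homo sapiens) for cytotoxicity, with a stated time of 3 days (a lower number here means that less compound is tolerated, a higher number that more compound is tolerated), compound 1 sits at a limit and not at a number. Compound 2 sits at the same limit. Compound 3 sits at the same limit. Within the data shown here, the only pair that differs in one place is compounds 1 and 3: a step that the two limits leave unreadable from compound 1 to compound 3, and the step is unreadable because of the limit of > 100000 nM in this assay, at which 3 of the 3 values shown sit; the two differ only in configuration as drawn (the fact that compounds 1 and 3 differ only in the configuration as drawn).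

Compound 4 `C[C@H](NC(=O)[C@]1(Cc2ccccc2)CCN1C(=O)OCc1ccccc1)C(=O)NC1CCCCC1` follows from compound 1 by cyclohexylamino in place of dimethylamino on a carbonyl carbon. Among the measured compounds shown here, no measured step touches the dimethylcarbamoyl group, and the one step that exists is unreadable, so nothing in the data points to a readable step in this assay in either direction. Compound 4 is therefore expected to remain at the limit, which would mean a step that the limit leaves unreadable from compound 1 to compound 4 that cannot be read. The estimate for compound 4 in this assay is 150000 nM, with a range from 60000 nM to 400000 nM, and the most probable outcome is that only a limit is reported.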

Compound 4, minimum cytotoxic concentration: > 100000 nM
Compound 4 ended at the assay's limit; the forecaster's own chance of this, stated with the estimate: 85%; the middle value does not contradict the limit.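

Among these compounds, compound 1 and compound 4 both stand at a limit of the assay, so no step between them can be read: the limit of > 100000 nM in this assay, at which 4 of the 4 values shown sit. The compounds shown leave open how far the tolerated concentration of each lies past that limit, and whether cyclohexylamino in place of dimethylamino changes it at all.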